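Carboxylic Acid to Ethyl Ester on a Shared Core

A few compounds are considered here, and "the series" means these few. Any claim that something is new, unique, unknown or untested is made for them only; others in the source may bear on it.

Compound 1 `CC1(C)OC(Nc2ccccc2)=C(C(=O)O)C1=O` — 44%
Compound 2 `O=C(O)C1=C(Nc2ccc(C(=O)O)cc2)OCC1=O` — 52%
Compound 3 `O=C(O)C1=C(Nc2ccccc2)OCC1=O` — 81%; 17% (2 entries)

Of the compounds shown here, three have been tested in a functional assay on the whole organism for inhibition, with Rattus norvegicus as the target, at a dose of 100 mg/kg by the intraperitoneal route; a lower number here means less inhibition, a higher number more inhibition at the dose given (going by the name of the read-out). Compound 1 gives 44%, the lowest of the two single numbers, and compound 2 gives 52%, which lies within the scatter of it. Compound 3 has no single number: its repeats, (the several entries of compound 3 in this assay, 81%; 17% (2 entries)), lie far apart, so the assay itself looks noisy here.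

Compound 4 `CCOC(=O)C1=C(Nc2ccccc2)OC(C)(C)C1=O` differs from compound 1 by ethyl in place of hydrogen on an oxygen next to a carbonyl group; that is, carboxy becomes ethoxycarbonyl. Going by the values given here, no measured pair shows this change, so its effect is unknown. Without such evidence, no step beyond the scatter is expected: the expected step of a number 2 percentage points lower from compound 1 to compound 4 (within the scatter) is small and uncertain in direction. Compound 4 is therefore estimated at 42%, with a range from 12% to 72%.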

Compound 4, a percentage reported as inhibition, in the whole organism at one dose (the size of the read-out at that dose, not a potency): 16%
Beside the measured number, compound 4's estimate is 26 percentage points above it; low and high end bracket the measured number.
By their numbers in this assay, from the lowest: compound 4; then compounds 1 and 2 (each within the scatter of the next).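

In this assay, going by these compounds alone, ethyl in place of hydrogen on an oxygen next to a carbonyl group gives a number 28 percentage points lower from compound 1 to compound 4 (beyond the scatter) on the shared core, the first measured step at this position. Carboxy thus gives more inhibition than ethoxycarbonyl in this one pair, whereas the earlier compounds offered no measured view of this change. That single pair needs caution, as repeats can lie far apart: the several entries of compound 3 in this assay, 81%; 17% (2 entries)

From the compounds shown here alone, whether the change acts alike on the core of compound 3 remains open. So does whether a methyl ester or a primary amide would match ethoxycarbonyl.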